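This account rests on a few compounds, and the source may have more. Where it says the series, first, only, none or still open, it means among the compounds named here.

Compound 1 `O=S(=O)(Nc1ccc(-c2nc3ccccc3o2)cc1)c1cccs1` gives 63000 nM in an assay on cells for inhibition of HSP60/HSP10 (Homo sapiens), with a stated time of 60 min; on this read-out higher numbers stand for weaker inhibition and lower numbers for stronger inhibition. Compound 2 `Cc1ccccc1S(=O)(=O)Nc1ccc2oc(-c3ccccc3)nc2c1` gives only a limit of the assay, > 100000 nM, in this assay; it sits at the limit of > 100000 nM in this assay, at which 1 of the 2 values shown sits. Compound 3 `CS(=O)(=O)Nc1ccc2oc(-c3ccccc3)nc2c1` carries methyl in place of 2-methylphenyl on a sulfonyl sulfur. For the measured compounds named here, no measured pair here differs in one place, so the size of such a step is not known from these data; with compound 2 at its limit, no step beyond the usual scatter is expected in this assay, in either direction. Compound 3 is therefore expected near 150000 nM, ranging from 50000 nM to 500000 nM, which means an expected step that the limit leaves unreadable from compound 2 to compound 3.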

Compound 3, half-maximal inhibitory concentration: > 100000 nM
Compound 3 was reported as a limit; the forecaster's own chance of this, stated with the estimate: 80%; the middle value is on the limit's open side.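

For the compounds shown here, compound 2 and compound 3 both stand as limits in this assay, so no step from one to the other can be read: the limit of > 100000 nM in this assay, at which 2 of the 3 values shown sit. Going by these compounds, whether methyl and 2-methylphenyl on a sulfonyl sulfur differ at all on this read-out remains open.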